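Swapping fluoro for chloro on a pendant aromatic ring

A few compounds are considered here, and "the series" means these few. Any claim that something is new, unique, unknown or untested is made for them only; others in the source may bear on it.

Of the compounds shown here, two have been tested in a functional assay on T-24 cells (Homo sapiens) for cytotoxicity, read by CCK-8 assay, with a stated time of 24 h (a lower number here means a stronger inhibitor, a higher number a weaker inhibitor), so far. Compound 1, `C/C(=C\c1cc(C2=CCCCC2)co1)C(N)=O`, carries a furan-type core with a cyclohexenyl substituent. In this assay compound 1 reaches only the limit of > 50000 nM, which is a boundary of the test rather than a number. Compound 2, `C/C(=C\c1cc(-c2ccc(F)cc2)cs1)C(N)=O`, carries a fluorophenyl group instead. In this assay compound 2 likewise reaches only the limit of > 50000 nM, again a boundary rather than a number. Thus compound 2 stands at the limit of > 50000 nM in this assay, at which 2 of the 2 values shown sit, and nothing separates it from compound 1 on the numbers shown.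

Compound 3, `C/C(=C\c1cc(-c2ccc(Cl)cc2)cs1)C(N)=O`, has not been measured yet. It differs from compound 2 in one place: chloro in place of fluoro on an aromatic carbon. Because the limit of > 50000 nM in this assay, at which 2 of the 2 values shown sit, leaves no room to read any step from the measured pair, no direction can be drawn from the data. The step from compound 2 to compound 3 is expected to be a step that the limit leaves unreadable from compound 2 to compound 3, which is no change beyond the scatter. Compound 3 is therefore estimated at 60000 nM, within a range from 20000 nM to 200000 nM, most likely again reported only as a limit.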

Compound 3, half-maximal inhibitory concentration: > 50000 nM
Compound 3: a limit, no number; the forecaster's own chance of this, stated with the estimate: 80%; the middle value lies beyond the limit too.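

In this assay compound 3 gives > 50000 nM, which is a limit and not a number. The change from fluoro to chloro between compound 2 and compound 3 cannot be read as a step, because all the results share one boundary: the limit of > 50000 nM in this assay, at which 3 of the 3 values shown sit.

The compounds shown leave open how far each one lies beyond that limit, and whether any change to the shared core would give a measurable value.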